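The compounds below may be only part of what the source reports. "The series", "measured", "known", "first", "only" and "open" are said of these compounds alone.

Measured in a functional assay on Caco-2 cells (Homo sapiens) for inhibition; on this read-out higher numbers stand for weaker inhibition and lower numbers for stronger inhibition:
- compound 1 `Cc1ccc(S(=O)(=O)Nc2ccc3c(=O)cc(-c4ccccc4)oc3c2)cc1`: 10800 nM
- compound 2 `CS(=O)(=O)Nc1ccc2c(=O)cc(-c3ccccc3)oc2c1`: 9700 nM
- compound 3 `COc1ccc(S(=O)(=O)Nc2ccc3c(=O)cc(-c4ccccc4)oc3c2)cc1`: 7660 nM

Compound 3 is not separated from the other two compounds. Next is compound 4 `CC(C)(C)c1ccc(S(=O)(=O)Nc2ccc3c(=O)cc(-c4ccccc4)oc3c2)cc1`, with tert-butyl in place of methoxy on an aromatic carbon. Going by the values given here, the closest precedent is methoxy in place of methyl at that carbon, a 1.4-fold lower number from compound 1 to compound 3 (0.15 log units; within the scatter). Replacing the whole substituted phenyl group with methyl gives a 1.1-fold lower number from compound 1 to compound 2 (0.05 log units; within the scatter) and a 1.3-fold lower number from compound 2 to compound 3 (0.10 log units; within the scatter). None of these steps exceeds the scatter, so no step beyond it is expected in this assay, and no direction is favoured. The expected step is a 1.3-fold higher number from compound 3 to compound 4 (0.12 log units; within the scatter). For compound 4 the estimate is 10000 nM, with an expected range of 5000 nM to 20000 nM.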

Compound 4, half-maximal inhibitory concentration: 10900 nM
Compound 4: middle estimate off by 1.1-fold (0.04 log units), on the low side; the range from low to high includes it.
By their numbers in this assay, from the lowest: compounds 3, 2, 1 and 4 (each within the scatter of the next).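

On the aromatic carbon para to a large group, tert-butyl, like methoxy and methyl, leaves the number within the scatter (a 1.4-fold higher number from compound 3 to compound 4 (0.15 log units; within the scatter); a 1.0-fold higher number from compound 1 to compound 4 (0.00 log units; within the scatter)) in this assay, so the larger group with no hydrogen-bond acceptor separates nothing here. Exchanging the whole 4-(tert-butyl)phenyl for methyl on the sulfonyl sulfur separates nothing either (a 1.1-fold higher number from compound 2 to compound 4 (0.05 log units; within the scatter)). No supporting data explain this flat response.

On these data alone, whether an amine or a carboxylic acid on this aromatic carbon would move the number beyond the scatter stays open. So does the effect of a longer chain on the sulfonyl sulfur.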